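The source may report more compounds than this note shows. Statements on the series, on what has been measured and on what is new or still open speak of the compounds shown alone.

Of the compounds shown here, two have so far been tested in a functional assay on A549 cells (Homo sapiens) for antiproliferative activity, read by sulforhodamine B assay, with a stated time of 48 h; a lower number here means a stronger inhibitor of growth, a higher number a weaker inhibitor of growth. Compound 1 `CC(C)CCc1c(OCCCCCC(=O)NO)ccc2ccc(=O)oc12` gives 870 nM, and compound 2 `CC(C)CCc1c(OCCCCCCCC(=O)NO)ccc(CCC(=O)NO)c1O` gives 2670 nM. Compound 2 therefore has the higher of the two numbers, and the gap lies beyond the usual scatter. Compound 3 `CC(C)CCc1c(OCCCCC(=O)NO)ccc(CCC(=O)NO)c1O` is compound 2 with a single change: hydroxycarbamoyl in place of 3-(hydroxycarbamoyl)propyl on a saturated chain carbon, four bonds along the chain from an oxygen on an aromatic ring. Hydroxycarbamoyl stands in place of 3-(hydroxycarbamoyl)propyl on a saturated chain carbon, four bonds along the chain from an oxygen on an aromatic ring, and this leaves a shorter chain. Among the compounds with values here, no measured pair shows this change alone: compound 1 and compound 2 differ in more than one place. A modest move towards a higher number in this assay is expected, though no change beyond the scatter remains possible. The expected move is an estimated 1.5-fold higher number from compound 2 to compound 3 (0.18 log units; within the scatter). For compound 3 the estimated value is 4000 nM, with an expected range of 1400 nM to 11000 nM.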

Compound 3, concentration for 50% growth inhibition: 10000 nM
Compound 3: middle estimate off by 2.5-fold (0.40 log units), on the low side; the measured number falls inside the stated range.
By their numbers in this assay, from the lowest: compound 1; then compound 2; then compound 3.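

Cutting the chain at this position, with hydroxycarbamoyl in place of 3-(hydroxycarbamoyl)propyl, gives a 3.7-fold higher number from compound 2 to compound 3 (0.57 log units; beyond the scatter) in this assay and so weakens growth inhibition. Within the data shown here, this is the first pair differing in this one place, and it shows that the length of this chain, which ends in the hydroxycarbamoyl group, can shift the result on its own; in this pair, the longer chain gives the lower number. No measurement here explains why the shorter chain does worse.

With only these two chain lengths compared in a single pair, the trend cannot be drawn as a line: a chain of intermediate length, or one longer than 6-(hydroxycarbamoyl)hexyl, could fall anywhere. On these data alone, it also remains open whether a carboxylic acid or a primary amide at the chain end would behave like hydroxycarbamoyl.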